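Sulfonamide head-group swap in the thiourea series

This account rests on a few compounds, and the source may have more. Where it says the series, first, only, none or still open, it means among the compounds named here.

Compound 1 `Cc1cc(NS(=O)(=O)c2ccc(N/C(S)=N\c3ccnc4cc(C(F)(F)F)ccc34)cc2)on1` is recorded in a functional assay on LoVo cells (Homo sapiens) for antiproliferative activity, read by sulforhodamine B assay, with a stated time of 48 h (a higher number here means a weaker inhibitor, a lower number a stronger inhibitor), as "not active" (no number reported), with no number attached. For the measured compounds named here, compound 2 `Cc1noc(NS(=O)(=O)c2ccc(N/C(S)=N\c3ccnc4cc(C(F)(F)F)ccc34)cc2)c1C` gives 67100 nM in this assay, and compound 3 `O=S(=O)(Nc1nccs1)c1ccc(N/C(S)=N\c2ccnc3cc(C(F)(F)F)ccc23)cc1` gives 67100 nM; compound 3 thus stands level with compound 2, the only numbered neighbour. Going by the values given here, the one step that connects the numbered entries, no change at the digits printed from compound 2 to compound 3 (within the scatter), is flat. Compound 4 `Cc1ccnc(NS(=O)(=O)c2ccc(N/C(S)=N\c3ccnc4cc(C(F)(F)F)ccc34)cc2)n1` arises from compound 3 by 4-methylpyrimidin-2-yl in place of 1,3-thiazol-2-yl on a sulfonamide nitrogen. Among the compounds with values here, the single step that bears on this place, the flat one from compound 2 to compound 3, points to no shift beyond the scatter, so the expected step of a 1.0-fold lower number from compound 3 to compound 4 (0.00 log units; within the scatter) is essentially none. Compound 4 is therefore estimated at 67000 nM in this assay, within the range 25000 nM to 180000 nM, with a real chance that only inactivity is recorded.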

Compound 4, half-maximal inhibitory concentration: 31000 nM
For compound 4 the middle estimate is 2.2-fold (0.33 log units) above the measured one; low and high end bracket the measured number.
By their numbers in this assay, from the lowest: compound 4; then compounds 2 and 3 (each within the scatter of the next).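

The sulfonamide nitrogen is no longer a flat position in this assay: 4-methylpyrimidin-2-yl gives a 2.2-fold lower number from compound 3 to compound 4 (0.34 log units; beyond the scatter), and against the other numbered head group a 2.2-fold lower number from compound 2 to compound 4 (0.34 log units; beyond the scatter). For the compounds shown here, this is the first step beyond the scatter, and it is modest; it comes with a six-membered ring in place of a five-membered one. Nothing measured here accounts for the step. The compounds shown cannot separate the effect of the pyrimidine ring from that of its methyl group. An unsubstituted pyrimidin-2-yl or a phenyl group on the same nitrogen remains an open comparison.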